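The source may hold more compounds than are shown below. What is called first, only, known or untested is meant among the compounds shown, and "the series" means these compounds.

Compound 1 `O=C(Nc1ccc2c(c1)B(O)OC2)c1ccccc1` is the parent here, and compound 2 `O=C(Nc1ccc2c(c1)B(O)OC2)c1ccccc1F` and compound 3 `O=C(Nc1ccc2c(c1)B(O)OC2)c1cccc(C(F)(F)F)c1` each add one group to it. In a functional assay on PBMC cells (Homo sapiens) for inhibition, read by HTRF, with stated times of 15 min and 24 h (on this read-out higher numbers stand for weaker inhibition and lower numbers for stronger inhibition), compound 1 gives > 100000 nM, which is a limit of the assay and not a number. Compound 2 gives > 10000 nM, which is also a limit. Compound 3 gives > 10000 nM, again a limit, and this is where the present step begins.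

Compound 4 `O=C(Nc1ccc2c(c1)B(O)OC2)c1cccc(C(F)(F)F)c1F` has fluoro in place of hydrogen on an aromatic carbon of compound 3, ortho to a trifluoromethyl group: fluoro in place of hydrogen on an aromatic carbon. The closest measured change is a step that the two limits leave unreadable from compound 1 to compound 2, where fluoro also replaces hydrogen. The other measured change is a step that the two limits leave unreadable from compound 1 to compound 3, with trifluoromethyl as the new group. Neither offers a size to carry over, so no clear shift in either direction is expected in this assay. The expected change is a step that the limit leaves unreadable from compound 3 to compound 4. For compound 4 the estimated value is 15000 nM, with an expected range from 3000 nM to 60000 nM.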

Compound 4, half-maximal inhibitory concentration: > 100000 nM
Compound 4: a limit, no number; the forecaster's own chance of this, stated with the estimate: 60%; middle value at least 6.6-fold (0.82 log units) away from the limit.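

Compound 4, like compound 2 and compound 3, gives only a limit and not a number, so neither of its steps, from compound 3 or from compound 2, can be read. The compounds shown leave open whether fluoro or trifluoromethyl changes inhibition at all in this assay.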